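Substituent swap on the shared core: nitro to fluoro

The compounds below may be only part of what the source reports. "The series", "measured", "known", "first", "only" and "open" are said of these compounds alone.

Compound 2 `O=[N+]([O-])c1ccccc1OCC1=NCCO1` is measured in a functional assay on the whole organism for inhibition, with Rattus norvegicus as the target, read by paw edema, with a stated time of 30 min, at a dose of 80 mg/kg by the oral route (a lower number here means a weaker effect, a higher number a stronger effect of the compound at the dose given), at 50.5%. Compound 1 `Cc1ccccc1OCC1=NCCO1` gives 55.3% in this assay. Among the measured compounds shown here, of the two numbers now known, compound 2 carries the lower one, but the only measured step, a number 4.8 percentage points lower from compound 1 to compound 2 (within the scatter), lies within the scatter, so the two compounds cannot be ordered against each other on this read-out.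

Compound 3 `Fc1ccccc1OCC1=NCCO1` is not yet measured. It differs from compound 2 by fluoro in place of nitro on an aromatic carbon. For the measured compounds named here, no measured step exchanges nitro for fluoro, so the one step that bears on the question is the exchange of methyl for nitro on the same aromatic carbon, which moved the percentage inhibition by a number 4.8 percentage points lower from compound 1 to compound 2 (within the scatter) and stayed inside the scatter. With one group swap at that carbon having produced no step beyond the scatter, a second swap there is expected to behave alike, with no clear direction.

Compound 3 is therefore expected to give 52% in this assay, with a range of 35% to 68%. The step of a number 1.5 percentage points higher from compound 2 to compound 3 (within the scatter) is expected to stay within the scatter.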

Compound 3, a percentage reported as inhibition, in the whole organism at one dose (the size of the read-out at that dose, not a potency): 60.1%
For compound 3 the middle estimate is 8.1 percentage points below the measured one, within the range that was stated.
By their numbers in this assay, from the lowest: compounds 2, 1 and 3 (each within the scatter of the next).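

Notes on the aromatic carbon of the shared core: in this assay the step of a number 9.6 percentage points higher from compound 2 to compound 3 (within the scatter) and the step of a number 4.8 percentage points higher from compound 1 to compound 3 (within the scatter) both stay within the scatter, and with the earlier methyl to nitro exchange this leaves methyl, nitro and fluoro at this place unordered on the percentage inhibition. Fluoro in place of nitro takes the substituent from 3 heavy atoms and 2 hydrogen-bond acceptors to 1 heavy atom and 0 hydrogen-bond acceptors, and even this change gives no step beyond the scatter. No measured evidence on the compounds bears on this result.

Whether any group on this aromatic carbon can move the read-out beyond the scatter stays open, as an amine, a carboxylic acid or a longer chain at this place lies outside the compounds shown. The read-out also gives the size of the effect at one dose and not a potency, so whether the three compounds would separate at other doses remains unresolved.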